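The compounds below may be only part of what the source reports. "The series", "measured", "known", "first", "only" and "open" are said of these compounds alone.

Two compounds of the series have numbers in an ADME assay on liver for metabolic stability, with Liver microsome (Rattus norvegicus) as the target, read by LC-MS, using microsomes, with a stated time of 5 h (on this read-out lower numbers stand for slow clearance and higher numbers for fast clearance), so far. Compound 1 `C[C@]1(O)C[C@@](c2cccc(C(F)(F)F)c2)([C@H](O)c2ccccn2)C1` gives 317 mL/min/kg in this assay, the lower of the two; compound 2 `CC(O)(c1ccccn1)C1(c2ccc(Cl)c(Cl)c2)CCC1` gives 6330 mL/min/kg, a gap well beyond the scatter. Compound 3 `C[C@]1(O)C[C@@](c2cccc(OC(F)(F)F)c2)([C@H](O)c2ccccn2)C1` is not yet measured. It differs from compound 1 by trifluoromethoxy in place of trifluoromethyl on an aromatic carbon. Nothing measured in the series tracks this change, so the step is expected to be small: from compound 1 a 1.3-fold higher number from compound 1 to compound 3 (0.10 log units; within the scatter) is estimated, with no clear direction beyond the scatter. For compound 3 the expected clearance is 400 mL/min/kg, between 150 mL/min/kg and 1000 mL/min/kg.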

Compound 3, clearance: 200 mL/min/kg
Estimate against measurement, compound 3: 2.0-fold (0.30 log units) above, within the range that was stated.
By their numbers in this assay, from the lowest: compounds 3 and 1 (each within the scatter of the next); then compound 2.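

On the aromatic carbon meta to a large group, trifluoromethoxy in place of trifluoromethyl gives a 1.6-fold lower number from compound 1 to compound 3 (0.20 log units; within the scatter) in this assay. Within the data shown here, this is the first one-place step, and it shows that this position accepts the extra oxygen with no change in clearance beyond the scatter. No measurement available bears on why the two groups read alike. Open, on these data alone, is whether an amine, a carboxylic acid or a longer chain on this carbon would move clearance beyond the scatter. Also open, as far as these compounds go, is whether the same exchange reads alike at another place on this ring.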